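This account rests on a few compounds, and the source may have more. Where it says the series, first, only, none or still open, it means among the compounds named here.

Measured so far:
compound 1 `O=c1[nH]c2ccccc2n1CCCN1CCC(C(O)(c2ccccc2)c2ccccc2)CC1` gives 7500 nM
compound 2 `O=c1[nH]c2ccccc2n1CCCCCN1CCN(C(c2ccccc2)c2ccccc2)CC1` gives 560 nM

In an assay on RPMI-8226 cells for antagonist activity at P2X purinoceptor 7 (Homo sapiens), read by calcium flux (a lower number here means a stronger inhibitor, a higher number a weaker inhibitor), compound 2 has the lowest of the two numbers; compound 1 is the nearest and its number is higher by a gap beyond the scatter. Compound 3 `Cc1cccc2ccn(CCCCN3CCN(C(c4ccccc4)c4ccccc4)CC3)c12` differs from compound 2 by a group of 10 heavy atoms (9 carbon, 1 nitrogen; one five-membered aromatic ring with 1 hetero atom, one six-membered aromatic ring of carbon only) in place of a group of 11 heavy atoms (8 carbon, 2 nitrogen, 1 oxygen; one five-membered aromatic ring with 2 hetero atoms, one six-membered aromatic ring of carbon only), on a saturated chain carbon, four bonds along the chain from an amine nitrogen in a ring. Within the data shown here, no measured pair shows this change, so its effect is unknown. The group that enters carries no hydrogen-bond donor, and the change from compound 2 to compound 3 is expected to weaken inhibition somewhat, a 2.1-fold higher number from compound 2 to compound 3 (0.33 log units; beyond the scatter), though a result within the scatter would not surprise. Compound 3 is estimated at 1200 nM in this assay, in the range 300 nM to 5000 nM.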

Compound 3, half-maximal inhibitory concentration: 2300 nM
Compound 3: middle estimate off by 1.9-fold (0.28 log units), on the low side, within the range that was stated.
By their numbers in this assay, from the lowest: compound 2; then compound 3; then compound 1.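

In this assay, among these compounds, the first step at this position, a 4.1-fold higher number from compound 2 to compound 3 (0.61 log units; beyond the scatter), shows that inhibition depends on the group at this saturated chain carbon, though a swap to 7-methyl-1H-indol-1-yl, which carries no hydrogen-bond donor, weakens it only modestly. No measurement offered here explains this loss of inhibition. The compounds shown leave open how an unsubstituted 1H-indol-1-yl or a primary amide would behave at this place, and so whether the loss follows the hydrogen-bond donor, the methyl group or some other part of the exchanged groups.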